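A Sulfonyl Pyridine in Place of a Cyclobutanone Amide

This account rests on a few compounds, and the source may have more. Where it says the series, first, only, none or still open, it means among the compounds named here.

Three measured compounds share one core and differ only in the group on the carbonyl carbon of the amide. Compound 1 `CC(O)c1cccc(C(=O)N[C@@H](C)Cn2ccc(-c3ccc(C#N)c(Cl)c3)n2)c1` carries a 3-(1-hydroxyethyl)phenyl group there. In an ADME assay on PC-3 cells (Homo sapiens) for cytotoxicity, read by CCK-8 assay, with a stated time of 6 days (a lower number here means a stronger inhibitor, a higher number a weaker inhibitor), compound 1 gives > 30000 nM, which is a limit of the assay and not a number. Compound 2 `C[C@@H](Cn1ccc(-c2ccc(C#N)c(Cl)c2)n1)NC(=O)c1ccccc1F` carries a 2-fluorophenyl group, and in this assay compound 2 gives > 30000 nM, again a limit. Compound 3 `C[C@@H](Cn1ccc(-c2ccc(C#N)c(Cl)c2)n1)NC(=O)C1CC(=O)C1` carries a 3-oxocyclobutyl group, and in this assay compound 3 gives > 30000 nM, also a limit. For the measured compounds named here, because all three sit at the limit of > 30000 nM in this assay, at which 3 of the 3 values shown sit, no step among them can be sized: a step that the two limits leave unreadable from compound 1 to compound 2, a step that the two limits leave unreadable from compound 1 to compound 3 and a step that the two limits leave unreadable from compound 2 to compound 3 all stay unreadable. Compound 3 therefore stands exactly where every measured compound stands, at the limit.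

Compound 4 `C[C@@H](Cn1ccc(-c2ccc(C#N)c(Cl)c2)n1)NS(=O)(=O)c1cccnc1` differs from compound 3 in (pyridin-3-yl)sulfonyl in place of (3-oxocyclobutyl)carbonyl on an amine nitrogen. The measured steps give no sign of any movement in this assay, so none beyond the scatter is expected from this change either. Compound 4 is expected to give about 40000 nM in this assay, within a range from 15000 nM to 100000 nM. The expected step is a step that the limit leaves unreadable from compound 3 to compound 4, essentially no change, most likely reported again as a limit.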

Compound 4, half-maximal inhibitory concentration: > 30000 nM
Compound 4: only a limit was reported; the forecaster's own chance of this, stated with the estimate: 80%; the middle value is on the limit's open side.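

In this assay compound 4 gives > 30000 nM, which is a limit of the assay and not a number. The steps from compound 2 and compound 3 to compound 4 therefore cannot be read: the limit of > 30000 nM in this assay, at which 4 of the 4 values shown sit.

The compounds shown leave open whether any group on the shared core would give a readable value in this assay.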